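The compounds below may be only part of what the source reports. "The series", "measured", "known", "first", "only" and "open" are said of these compounds alone.

Compound 1 `Cc1ccc(NC(=S)NC(=O)c2ccc(OCc3cccc(Cl)c3Cl)cc2)cc1-c1nc2ccccc2[nH]1` carries a thiourea linker between its two parts. In a functional assay on HT-29 cells (Homo sapiens) for inhibition, read by MTT assay, with a stated time of 48 h (a lower number here means a stronger inhibitor, a higher number a weaker inhibitor), compound 1 gives 63700 nM. Compound 2 `Cc1ccc(COc2ccc(C(=O)NC(=S)Nc3ccc(C)c(-c4nc5ccccc5[nH]4)c3)cc2)cc1` keeps that linker but differs in one place: 4-methylphenyl in place of 2,3-dichlorophenyl on a saturated chain carbon bound to an oxygen on an aromatic ring. In this assay compound 2 gives 14200 nM, a step of a 4.5-fold lower number from compound 1 to compound 2 (0.65 log units; beyond the scatter).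

Compound 3 `Cc1ccc(NC(=O)NC(=O)c2ccc(OCc3cccc(Cl)c3Cl)cc2)cc1-c1nc2ccccc2[nH]1` has a urea linker in place of the thiourea of compound 1; the difference between these two cores is not broken down here. In this assay compound 3 gives 48500 nM, which is within the scatter of compound 1, so the two cannot be ordered.

Compound 4 `Cc1ccc(COc2ccc(C(=O)NC(=O)Nc3ccc(C)c(-c4nc5ccccc5[nH]4)c3)cc2)cc1` has not yet been measured. It stands to compound 3 as compound 2 stands to compound 1: 4-methylphenyl in place of 2,3-dichlorophenyl on a saturated chain carbon bound to an oxygen on an aromatic ring. The place is the same in both pairs, so this is the same change made on the urea core.

Among the compounds with values here, compound 4 is expected to show a step of a 4.4-fold lower number from compound 3 to compound 4 (0.64 log units; beyond the scatter), resting on the single earlier example of a 4.5-fold lower number from compound 1 to compound 2 (0.65 log units; beyond the scatter) seen on the thiourea core. On that basis compound 4 is estimated at 11000 nM, with a range from 4000 nM to 30000 nM.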

Compound 4, half-maximal inhibitory concentration: 5110 nM
Estimate against measurement, compound 4: 2.2-fold (0.33 log units) above; the range from low to high includes it.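

On the urea core, replacing 2,3-dichlorophenyl with 4-methylphenyl gives a 9.5-fold lower number from compound 3 to compound 4 (0.98 log units; beyond the scatter), so the number falls here as it did on the thiourea core. Set side by side, the two steps run in the same direction and their sizes cannot be told apart: the same change on two cores in this assay, a 4.5-fold lower number (0.65 log units; beyond the scatter) from compound 1 to compound 2 and a 9.5-fold lower number (0.98 log units; beyond the scatter) from compound 3 to compound 4, 2.1-fold (0.33 log units) apart, within the scatter of two such steps. In this assay, within the data shown here, then, the change carried over from one core to the other, but this rests on only two pairs and does not show why the number falls, nor whether the same would hold on a third core or in a different assay.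

With only these two groups at this place, the compounds shown leave open whether the lower number follows from losing the two chlorines or from gaining the methyl. They also leave open how an amine, a carboxylic acid or a longer chain in place of the 4-methylphenyl would behave.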